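Nitro Substitution on a Hydroxamic Acid Cytotoxicity Series

The source may report more compounds than this note shows. Statements on the series, on what has been measured and on what is new or still open speak of the compounds shown alone.

Measured compounds:
compound 1 `COc1ccc2nc(NC(=O)CCCCC(=O)NO)sc2c1` 15.3 ug/mL
compound 2 `O=C(CCCCCCC(=O)Nc1nc2ccccc2s1)NO` 5.44 ug/mL
compound 3 `CS(=O)(=O)c1ccc2nc(NC(=O)CCCCC(=O)NO)sc2c1` > 30 ug/mL

In a functional assay on PC-3 cells (Homo sapiens) for cytotoxicity (a lower number here means a stronger inhibitor, a higher number a weaker inhibitor), compound 2 gives the lowest number of the two values read as numbers; compound 1 stands nearest, and the step between them lies beyond the scatter. For compound 3 the result is a limit, (the limit of > 30 ug/mL in this assay, at which 1 of the 3 values shown sits), not a number.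

Compound 4 `O=C(CCCCCCC(=O)Nc1nc2ccc([N+](=O)[O-])cc2s1)NO` differs from compound 2 at the shared core: nitro in place of hydrogen on an aromatic carbon.

Going by the values given here, the only measured step that changes a substituent on an aromatic carbon of the shared core is an at least 1.9-fold higher number from compound 1 to compound 3 (0.29 log units; that floor lies within the scatter), whose floor lies within the scatter, so it shows at most that such a change did not lower the number. Among the compounds with values here, no step with a nitro group has been measured. Compound 4 is therefore expected to give a number at or somewhat above that of compound 2, the step of a 1.7-fold higher number from compound 2 to compound 4 (0.22 log units; within the scatter) being estimated as modest. For compound 4 the estimate is 9 ug/mL, between 3.5 ug/mL and 30 ug/mL.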

Compound 4, half-maximal inhibitory concentration: 1.28 ug/mL
For compound 4 the middle estimate is 7.0-fold (0.85 log units) above the measured one, and the stated range ends above it.
By their numbers in this assay, from the lowest: compound 4; then compound 2; then compound 1. At a limit, above all of these: compound 3.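

Nitro in place of hydrogen on this aromatic carbon, meta to a fused ring and para to a fused ring, gives in this assay a 4.3-fold lower number from compound 2 to compound 4 (0.63 log units; beyond the scatter), so a substituent here can lower the number and not only leave it unchanged or raise it. Going by these compounds alone, the one earlier step that changed a substituent on an aromatic carbon of the shared core, an at least 1.9-fold higher number from compound 1 to compound 3 (0.29 log units; that floor lies within the scatter), gave no sign of this, and the new step is the first of its kind that lies beyond the scatter. Nothing measured here gives a reason for the lower number with nitro.

The compounds shown leave open whether an amine or a carboxylic acid on this carbon would move the number the same way. Nor does any pair shown separate the chain from the substituent, since compound 1 and compound 2 differ in more than one place.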